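The source may report more compounds than this note shows. Statements on the series, on what has been measured and on what is new or still open speak of the compounds shown alone.

Three close relatives built on one shared core have been tested in an ADME assay on Vero cells (Chlorocebus sabaeus) for cytotoxicity, read by neutral red uptake, tested at 98 ug/mL; on this read-out higher numbers stand for a weaker effect at the one concentration tested and lower numbers for a stronger effect. Compound 1 `O=C1CSC(c2ccc(Cl)cc2)N1CCN1CCCCC1` gives 74%. Compound 2 `O=C1CSC(c2ccccc2Cl)N1CCN1CCCCC1` gives 94%, and the step of a number 20 percentage points higher from compound 1 to compound 2 (beyond the scatter) is the only one among these three that crosses the usual scatter. Compound 3 `COc1cccc(C2SCC(=O)N2CCN2CCCCC2)c1` gives 84%; this number sits between the other two, and the values of compound 1 and compound 2 each lie within the scatter of it, so no order among the three can be claimed.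

Compound 4 `O=C1CSC(c2cccc(Cl)c2)N1CCN1CCCCC1` has not yet been measured. The change from compound 3 to compound 4 is chloro in place of methoxy on an aromatic carbon. Within the data shown here, no measured step exchanges a methoxy for a chloro, so the only guide is that the three known compounds, with a chloro at two positions and a methoxy at a third, all fall in a narrow band. Compound 4 is therefore expected to land near compound 3, with a step of no change at the digits printed from compound 3 to compound 4 (within the scatter) that stays within the scatter. The estimate for compound 4 is 84%, within 66% to 100%.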

Compound 4, a percentage reported as activity, at one concentration (the size of the read-out at that concentration, not a potency): 100%
Estimate against measurement, compound 4: 16 percentage points below; low and high end bracket the measured number.
By their numbers in this assay, from the lowest: compounds 1, 3, 2 and 4 (each within the scatter of the next, the first and the last beyond it).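

In this assay, the swap of chloro for methoxy on this aromatic carbon gives the first direct read of a group change at this position (a number 16 percentage points higher from compound 3 to compound 4 (beyond the scatter)), so the identity of the group matters here and not only where a chloro sits. Among the chloro compounds, 3-chlorophenyl stands clearly apart from 4-chlorophenyl (a number 26 percentage points higher from compound 1 to compound 4 (beyond the scatter)) but cannot be told apart from 2-chlorophenyl (a number 6 percentage points higher from compound 2 to compound 4 (within the scatter)), which leaves 4-chlorophenyl as the one chloro placement separated from both others. Nothing available explains these differences. On these data alone, what a hydroxy group, an amine or a carboxylic acid would give on this same aromatic carbon stays open. Also open, as far as these compounds go, is whether methoxy at the other two ring places would follow the chloro compounds.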